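A few compounds are considered here, and "the series" means these few. Any claim that something is new, unique, unknown or untested is made for them only; others in the source may bear on it.

Among the compounds with values here, compound 1 `O=C(O)CCCc1ccccc1-c1cccc(-c2ccccc2OCc2ccccc2)c1` is one of two compounds measured in an assay on HEK293 cells for binding affinity to prostaglandin E2 receptor EP3 subtype (Homo sapiens) (a higher number here means a weaker inhibitor, a lower number a stronger inhibitor), and it gives the higher of the two numbers: in this assay compound 1 gives 590 nM. The other measured compound is compound 2 `O=C(O)CCc1ccccc1-c1cc(-c2ccccc2OCc2ccccc2)cs1`, which shares the benzyloxyphenyl end and the acid-bearing phenyl ring but carries a different ring in the middle; in this assay compound 2 gives 27 nM, a lower number than that of compound 1 and a gap that lies beyond the usual scatter. Within the data shown here, no single-point step between these two is available, so the two values can only be set side by side.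

Compound 3 `CC(Cc1ccccc1-c1cccc(-c2ccccc2OCc2ccccc2)c1)C(=O)O` has not yet been measured. It keeps the core of compound 1 and differs only in the acid-bearing chain: 1-carboxyethyl in place of 2-carboxyethyl on a saturated chain carbon bound to an aromatic carbon. Among the measured compounds shown here, nothing among the measured compounds tests this particular rearrangement, so the size of its effect is open. The step from compound 1 to compound 3 in this assay is expected to be small, within or just beyond the scatter, and if anything towards a higher number, a 1.5-fold higher number from compound 1 to compound 3 (0.18 log units; within the scatter). Compound 3 is therefore estimated at 900 nM, with a range from 250 nM to 3500 nM.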

Compound 3, inhibition constant: 820 nM
For compound 3 the middle estimate is 1.1-fold (0.04 log units) above the measured one, and the stated range covers the measured number.
By their numbers in this assay, from the lowest: compound 2; then compounds 1 and 3 (each within the scatter of the next).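

In this assay, putting 1-carboxyethyl in place of 2-carboxyethyl on a saturated chain carbon bound to an aromatic carbon gives a 1.4-fold higher number from compound 1 to compound 3 (0.14 log units; within the scatter). Within the data shown here, this is the first comparison in the set in which only one place differs, and it shows that this rearrangement of the same atoms, also readable as 3-carboxypropyl to 2-carboxypropyl, cannot be told apart from the chain of compound 1 on the core of compound 1. Nothing measured alongside this result bears on it, so the step stands as a bare observation.

The compounds shown leave open whether the same rearrangement would also pass within the scatter on the core of compound 2, which gives 27 nM and so lies far from both compound 1 and compound 3 in its printed value. They also leave open whether a hydroxyl group or a longer chain at this place, or an amide or a tetrazole in place of the carboxylic acid, would shift the number in this assay.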